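Adding a hydroxy group to compound 3

A few compounds are considered here, and "the series" means these few. Any claim that something is new, unique, unknown or untested is made for them only; others in the source may bear on it.

In a functional assay on HT-29 cells (Homo sapiens) for inhibition, read by MTT assay, with a stated time of 48 h (a higher number here means a weaker inhibitor, a lower number a stronger inhibitor), the measured compounds read as follows
compound 1 (`COc1cc(-c2cc(-c3ccc(C)cc3)nc(-c3ccccc3)n2)cc(OC)c1OC`) gives > 25000 nM (a limit)
compound 2 (`COc1cc(-c2cc(-c3cccc(O)c3)nc(-c3ccccc3)n2)cc(OC)c1OC`) gives > 25000 nM (a limit)
compound 3 (`COc1cc(-c2cc(-c3ccccc3)nc(-c3ccccc3)n2)cc(OC)c1OC`) gives 7930 nM (a number)

Compound 3 (7930 nM) is the only one of the three with a number in this assay. The values of compound 1 and compound 2 are limits. Compound 4 (`COc1cc(-c2cc(-c3ccc(O)cc3)nc(-c3ccccc3)n2)cc(OC)c1OC`) differs from compound 3 by a single change (hydroxy in place of hydrogen on an aromatic carbon), phenyl to 4-hydroxyphenyl, with hydroxy in place of hydrogen on an aromatic carbon, para to a large group.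

For the measured compounds named here, two measured steps bear on this change, and both are minimum sizes. Hydrogen in place of hydroxy gave an at least 3.1-fold lower number from compound 2 to compound 3 (0.49 log units; beyond the scatter), and hydrogen in place of methyl gave an at least 3.1-fold lower number from compound 1 to compound 3 (0.49 log units; beyond the scatter), so a new substituent on compound 3 is expected to raise the number. The estimated step in this assay is a 2.5-fold higher number from compound 3 to compound 4 (0.40 log units; beyond the scatter), toward weaker inhibition. Compound 4 is estimated at 20000 nM, with an expected range from 7000 nM to 50000 nM.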

Compound 4, half-maximal inhibitory concentration: 11300 nM
Estimate against measurement, compound 4: 1.8-fold (0.25 log units) above; the range from low to high includes it.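

In this assay, hydroxy in place of hydrogen, para to a large group, gives a 1.4-fold higher number from compound 3 to compound 4 (0.15 log units; within the scatter), so this position can carry a hydroxy group without a step beyond the scatter, which the 4-methylphenyl of compound 1 and the 3-hydroxyphenyl of compound 2 had not shown. The placing of the group and its identity both matter here: 4-hydroxyphenyl in place of 3-hydroxyphenyl gives an at least 2.2-fold lower number from compound 2 to compound 4 (0.34 log units; beyond the scatter), and hydroxy in place of methyl gives an at least 2.2-fold lower number from compound 1 to compound 4 (0.34 log units; beyond the scatter). Both of these steps are minimum sizes, set by a limit: the limit of > 25000 nM in this assay, at which 2 of the 4 values shown sit.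

As far as these compounds go, it remains open whether other groups in this place, such as an amine, a carboxylic acid or a longer chain, would fare like hydroxy or like methyl. From the compounds shown here alone, how far compound 1 and compound 2 lie beyond their limits also remains open.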